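Capping the hydroxy group of compound 3

The compounds below may be only part of what the source reports. "The series", "measured", "known", "first", "only" and "open" are said of these compounds alone.

In a functional assay on MDA-MB-231 cells (Homo sapiens) for antiproliferative activity, read by luminescence, with a stated time of 24 h (on this read-out higher numbers stand for weaker inhibition and lower numbers for stronger inhibition), compound 3 `Cc1c(C)c2c(c(C)c1O)CCC(C)(COc1ccc(/C=C3\SC(=O)NC3=O)cc1)O2` gives 16600 nM. This is the higher of the two true numbers, the other being compound 2 `Cc1c(C)c2c(c(C)c1OC(=O)CCCC[C@@H]1SC[C@@H]3NC(=O)N[C@@H]31)CCC(C)(COc1ccc(CC3SC(=O)NC3=O)cc1)O2` at 6500 nM, and the gap between them lies beyond the scatter. Compound 1 `Cc1c(C)c2c(c(C)c1OC(=O)CCC(=O)O)CCC(C)(COc1ccc(CC3SC(=O)NC3=O)cc1)O2` gives > 25000 nM, which is a limit of the assay.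

Compound 4 `Cc1c(C)c2c(c(C)c1OC(=O)OC(C)(C)C)CCC(C)(COc1ccc(/C=C3\SC(=O)NC3=O)cc1)O2` carries tert-butoxycarbonyl in place of hydrogen on an oxygen on an aromatic ring. Among the measured compounds shown here, no measured step covers this change. For the measured compounds named here, the only one that alters a group on that oxygen is an at least 3.8-fold lower number from compound 1 to compound 2 (0.58 log units; beyond the scatter). It shows that this assay can respond to that group, but both of its compounds already carry a group there, and both differ from compound 3 elsewhere as well. It therefore gives only loose guidance on direction and little on size. Only a small move toward a lower number is expected, not clearly beyond the scatter, as the estimated 1.8-fold lower number from compound 3 to compound 4 (0.27 log units; within the scatter). For compound 4 the estimated value is 9000 nM, with an expected range of 3500 nM to 22000 nM.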

Compound 4, half-maximal inhibitory concentration: 3300 nM
Compound 4: the middle estimate sits 2.7-fold (0.44 log units) above what was measured; measured number below the stated range.
By their numbers in this assay, from the lowest: compounds 4 and 2 (each within the scatter of the next); then compound 3. At a limit, above all of these: compound 1.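

In this assay the change of hydroxy to (tert-butoxycarbonyl)oxy gives a 5.0-fold lower number from compound 3 to compound 4 (0.70 log units; beyond the scatter). Among the compounds shown here, this is the first step here that starts from the free hydroxy group and alters nothing else, so it shows that capping this oxygen on an aromatic ring moves the number by itself; compounds 1 and 2 could not show this, as both already carry a group there. The data shown include no measurement that accounts for the step.

On these data alone, it remains open whether an acetyl ester, an amine-bearing carbamate or a longer chain on that oxygen would move the number the same way. Also open, as far as these compounds go, is what the carbon-carbon double bond of compounds 3 and 4 contributes, since compounds 1 and 2 differ from them in more than one place.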